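Fluoro on a Benzyl Group: Expected Effect on Microsomal Stability

A few compounds are considered here, and "the series" means these few. Any claim that something is new, unique, unknown or untested is made for them only; others in the source may bear on it.

Measured compounds:
compound 1, `CN1CCN(c2cc3c(cc2F)c(=O)c(-c2nnc(Cc4ccccc4)o2)cn3Cc2ccc(Cl)cc2)CC1`, 20% in an ADME assay on microsomes from liver (Homo sapiens) for metabolic stability, with a stated time of 1 h; on this read-out higher numbers stand for a more stable compound and lower numbers for a less stable compound
compound 2, `CN1CCN(c2cc3c(cc2F)c(=O)c(-c2nnc(Cc4ccccc4)o2)cn3Cc2ccc(C(F)(F)F)cc2F)CC1`, 20% in this assay

On the numbers shown, compound 2 stands level with compound 1: the step of no change at the digits printed from compound 1 to compound 2 (within the scatter) lies within the scatter, although it swaps one benzyl substituent pattern for another on the saturated carbon bound to the aromatic nitrogen. Compound 3, `CN1CCN(c2cc3c(cc2F)c(=O)c(-c2nnc(Cc4ccc(F)cc4)o2)cn3Cc2ccc(C(F)(F)F)cc2F)CC1`, is not yet measured. It differs from compound 2 by fluoro in place of hydrogen on an aromatic carbon, that is, on the other benzyl group of the shared core, the one attached to the five-membered ring. Within the data shown here, only one measured step exists, and it concerns a different benzyl group; it showed no change beyond the scatter. Among the measured compounds shown here, no measured step touches the position altered in compound 3, so the expectation rests on the single observation that a change of substituents on a benzyl group left this assay's read-out unmoved. On that basis the step from compound 2 to compound 3 is expected to be small, a number 2 percentage points higher from compound 2 to compound 3 (within the scatter), with no direction beyond the scatter. Compound 3 is therefore estimated at 22%, within 10% to 38%.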

Compound 3, percent of the compound remaining: 20%
For compound 3 the middle estimate is 2 percentage points above the measured one; the measured number falls inside the stated range.
By their numbers in this assay, from the lowest: compounds 1, 2 and 3 (each within the scatter of the next).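

In this assay, fluoro in place of hydrogen on an aromatic carbon, para to a large group, gives no change at the digits printed from compound 2 to compound 3 (within the scatter), so the benzyl group attached to the five-membered ring now has a measured step of its own. The earlier compounds shown here offered only a step on the other benzyl group, no change at the digits printed from compound 1 to compound 2 (within the scatter), and these two steps now show that a change on either benzyl group of the shared core left this read-out where it was, with none of the three compounds going against that. Nothing available bears on why the read-out did not respond to the new fluoro.

The compounds shown leave open whether this position would respond the same way to a group other than fluoro, such as methoxy, a nitrile or an amine in the same place on the ring. They also leave open whether a change away from the two benzyl groups, for instance a longer chain in place of the methyl on the shared core, would move the read-out at all.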